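A few compounds are considered here, and "the series" means these few. Any claim that something is new, unique, unknown or untested is made for them only; others in the source may bear on it.

Working notes on the series, read in a functional assay on A549 cells (Homo sapiens) for inhibition, read by MTT assay, with a stated time of 72 h; on this read-out higher numbers stand for weaker inhibition and lower numbers for stronger inhibition. Compound 1 `COc1ccccc1-c1csc2cnc(Nc3ccc(NC(=O)[C@H]4CCCNC4)cc3)nc12` gives 500 nM. Compound 2 `COc1ccccc1-c1csc2cnc(Nc3ccc(C(=O)NC4CCNCC4)cc3C)nc12` gives 3420 nM, the higher of the two numbers and beyond the scatter of compound 1, so it is the weaker inhibitor of the pair. Compound 3 `COc1ccccc1-c1csc2cnc(Nc3ccc(C(=O)NC4CCNCC4)cc3C(F)(F)F)nc12` has trifluoromethyl in place of methyl on an aromatic carbon of compound 2: trifluoromethyl in place of methyl on an aromatic carbon. For the measured compounds named here, no measured step covers this change, so no shift beyond the scatter is expected, and the estimated step is a 1.1-fold lower number from compound 2 to compound 3 (0.06 log units; within the scatter). The estimate for compound 3 is 3000 nM, with an expected range of 1000 nM to 9000 nM.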

Compound 3, half-maximal inhibitory concentration: 4110 nM
Compound 3: the middle estimate sits 1.4-fold (0.14 log units) below what was measured, within the range that was stated.
By their numbers in this assay, from the lowest: compound 1; then compounds 2 and 3 (each within the scatter of the next).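

For the compounds shown here, the first measured step at this position, on the aromatic carbon ortho to a large group, is trifluoromethyl in place of methyl: a 1.2-fold higher number from compound 2 to compound 3 (0.08 log units; within the scatter). On this read-out, the two groups cannot be told apart with the (piperidin-4-yl)carbamoyl group in place. No available data explain this result.

As far as these compounds go, it remains open whether hydrogen, chlorine or an amine on this carbon would separate from methyl beyond the scatter. Compound 1 differs from compound 2 in more than one place, so its number says nothing about this position.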